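Replacing a branched amine with a ring: compound 3 to compound 4

The source may hold more compounds than are shown below. What is called first, only, known or untested is meant among the compounds shown, and "the series" means these compounds.

The shared core is a coumarin-bearing pyrazoline carrying a small side chain on its amide carbonyl. Compound 1 `O=C(CCl)N1N=C(c2cc3ccccc3oc2=O)CC1c1ccccc1` holds a chloro group there and gives 2980 nM in a functional assay on PC-3 cells (Homo sapiens) for cytotoxicity, read by MTT assay, with a stated time of 48 h; a higher number here means a weaker inhibitor, a lower number a stronger inhibitor. Compound 2 `CC(C)CNCC(=O)N1N=C(c2cc3ccccc3oc2=O)CC1c1ccccc1`, with isobutylamino in that place, gives 1920 nM in this assay, a step of a 1.6-fold lower number from compound 1 to compound 2 (0.19 log units; within the scatter). Compound 3 `CC(C)(C)NCC(=O)N1N=C(c2cc3ccccc3oc2=O)CC1c1ccccc1`, with (tert-butyl)amino, gives 16400 nM in this assay and stands highest of the three, the steps being a 5.5-fold higher number from compound 1 to compound 3 (0.74 log units; beyond the scatter) and an 8.5-fold higher number from compound 2 to compound 3 (0.93 log units; beyond the scatter).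

Compound 4 `O=C(CN1CCCC1)N1N=C(c2cc3ccccc3oc2=O)CC1c1ccccc1` differs from compound 3 by pyrrolidin-1-yl in place of (tert-butyl)amino on a saturated chain carbon bound to a carbonyl carbon. For the measured compounds named here, no measured step changes an amine in exactly this way; the closest guide is an 8.5-fold higher number from compound 2 to compound 3 (0.93 log units; beyond the scatter), which shows that swapping the group on this nitrogen can move the number well beyond the scatter. Since compound 3 is the outlier among the three, the expectation is that compound 4 returns toward the numbers of compound 1 and compound 2, an estimated step of a 4.7-fold lower number from compound 3 to compound 4 (0.67 log units; beyond the scatter). Compound 4 is therefore expected to give about 3500 nM in this assay, within a range of 1200 nM to 10000 nM.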

Compound 4, half-maximal inhibitory concentration: 50200 nM
The estimate for compound 4 lay 14-fold (1.16 log units) below the measured number; the measured number lies above the stated range.
By their numbers in this assay, from the lowest: compounds 2 and 1 (each within the scatter of the next); then compound 3; then compound 4.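

Compound 3 turns out not to be a lone outlier among the amines at this position: in this assay the pyrrolidin-1-yl group moves the number further up (a 3.1-fold higher number from compound 3 to compound 4 (0.49 log units; beyond the scatter)) and leaves it far from both the isobutylamino compound (a 26-fold higher number from compound 2 to compound 4 (1.42 log units; beyond the scatter)) and the chloro compound (a 17-fold higher number from compound 1 to compound 4 (1.23 log units; beyond the scatter)). Pyrrolidin-1-yl and (tert-butyl)amino hold the same count of heavy atoms, so that count alone does not set the number here; the entering group instead brings a ring and has no hydrogen-bond donor. Nothing measured here explains the rise.

These compounds cannot separate the presence of the ring from the loss of the amine hydrogen, as both changes arrive together in compound 4. An open-chain diethylamino group, which lacks that hydrogen but has no ring, or a piperidine or morpholine ring would help to pull the two apart.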